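The compounds below may be only part of what the source reports. "The series", "measured", "known", "first", "only" and "open" are said of these compounds alone.

- compound 1 `C=CS(=O)(=O)N1CCN(c2ncnc3ccc(-c4ccccc4)cc23)CC1`: 47900 nM
- compound 2 `C=CS(=O)(=O)N1CCN(c2ncnc3sc(-c4cn(C)nc4C(F)(F)F)cc23)CC1`: 10400 nM
- compound 3 `CN1CCN(c2ccc(-c3cc4c(N5CCN(S(=O)(=O)/C=C/c6ccccc6)CC5)ncnc4s3)cc2)CC1`: 5900 nM

These values come from a functional assay on MDA-MB-231 cells (Homo sapiens) for antiproliferative activity, read by MTT assay, with a stated time of 48 h; a higher number here means a weaker inhibitor, a lower number a stronger inhibitor. Compound 3, at 5900 nM, has the lowest number of the three, but it cannot be separated from compound 2. The gap between them lies within the usual scatter. The gap from compound 3 up to compound 1 lies beyond that scatter.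

The next compound to consider is compound 4 `COc1ccc(NC(=O)N2CCN(c3ncnc4sc(-c5ccc(N6CCN(C)CC6)cc5)cc34)CC2)cc1`. It keeps the rest of compound 3 and places (4-methoxyphenyl)carbamoyl in place of (2-phenylethenyl)sulfonyl on an amine nitrogen in a ring. All three measured compounds carry a sulfonyl group on that nitrogen, so none of them shows what the new group does in this assay. The expectation therefore stays anchored to compound 3 at 5900 nM. The expected change, a 1.0-fold higher number from compound 3 to compound 4 (0.01 log units; within the scatter), is small, with no clear shift beyond the scatter in either direction. In this assay the estimate for compound 4 is 6000 nM, with an expected range of 1500 nM to 24000 nM.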

Compound 4, half-maximal inhibitory concentration: 20900 nM
Beside the measured number, compound 4's estimate is 3.5-fold (0.54 log units) below it, and the stated range covers the measured number.
By their numbers in this assay, from the lowest: compounds 3, 2 and 4 (each within the scatter of the next, the first and the last beyond it); then compound 1.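

In this assay, putting (4-methoxyphenyl)carbamoyl in place of (2-phenylethenyl)sulfonyl on this ring nitrogen gives a 3.5-fold higher number from compound 3 to compound 4 (0.55 log units; beyond the scatter), a modest step that shows the assay responds to a change of group at this position, something the three sulfonyl compounds could not show. Both groups have 11 heavy atoms and one six-membered aromatic ring of carbon only, so the number moves even though those counts stay the same. No measurement here accounts for the step.

Going by these compounds, this single swap changes the sulfonyl link and the rest of the group together, so the role of each part stays open. A phenylcarbamoyl without the methoxy, or a plain acetyl, on the same nitrogen would help to separate them.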